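Aryl swap on the anilino nitrogen of a quinazoline-linked sulfonamide

The compounds below may be only part of what the source reports. "The series", "measured", "known", "first", "only" and "open" are said of these compounds alone.

Measured compounds: compound 1 `COc1cc2ncnc(Nc3cccc(Br)c3)c2cc1OCCCCC(=O)Nc1ccc(S(N)(=O)=O)cc1` with 14900 nM; compound 2 `COc1ccccc1Nc1ncnc2cc(OC)c(OCCCCC(=O)Nc3ccc(S(N)(=O)=O)cc3)cc12` with 24100 nM.

Compound 1 and compound 2 were tested in a functional assay on A549 cells (Homo sapiens) for antiproliferative activity, read by MTT assay, with a stated time of 72 h; on this read-out lower numbers stand for stronger inhibition and higher numbers for weaker inhibition. Within the data shown here, compound 2 has the highest of the two numbers; its only neighbour is compound 1, with the step of a 1.6-fold higher number from compound 1 to compound 2 (0.21 log units; within the scatter).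

Compound 3 `CCc1ccc(Nc2ncnc3cc(OC)c(OCCCCC(=O)Nc4ccc(S(N)(=O)=O)cc4)cc23)cc1` has not been measured. It differs from compound 2 by 4-ethylphenyl in place of 2-methoxyphenyl on a nitrogen on an aromatic ring. Among the measured compounds shown here, the one step that bears on this change is the exchange of the aryl group on the same nitrogen, a 1.6-fold higher number from compound 1 to compound 2 (0.21 log units; within the scatter), which stayed within the scatter. With no other evidence, no step beyond the scatter in either direction is expected in this assay for compound 3; the expected step is a 1.1-fold lower number from compound 2 to compound 3 (0.06 log units; within the scatter). Compound 3 is estimated at 21000 nM, with a range from 8000 nM to 55000 nM.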

Compound 3, half-maximal inhibitory concentration: 12100 nM
Compound 3: middle estimate off by 1.7-fold (0.24 log units), on the high side, and the stated range covers the measured number.
By their numbers in this assay, from the lowest: compounds 3, 1 and 2 (each within the scatter of the next).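

In this assay a third aryl group on this nitrogen again leaves the number within the scatter, with a 2.0-fold lower number from compound 2 to compound 3 (0.30 log units; within the scatter) and with a 1.2-fold lower number from compound 1 to compound 3 (0.09 log units; within the scatter) as well. Among these three compounds, the position therefore takes 3-bromophenyl, 2-methoxyphenyl and 4-ethylphenyl without any step beyond the scatter, and this holds even though the hydrogen-bond acceptor of 2-methoxyphenyl is absent from 4-ethylphenyl at an equal heavy-atom count. No measurement is available that would account for these numbers.

As far as these compounds go, it remains open whether a carboxylic acid or an amine on this phenyl ring, or a cyclohexyl or benzyl group on the nitrogen in its place, would move the number beyond the scatter. The compounds also leave open how a shorter or longer chain to the sulfonamide-bearing amide would behave.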